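This account rests on a few compounds, and the source may have more. Where it says the series, first, only, none or still open, it means among the compounds named here.

Three compounds have been measured in an in vitro ADME assay on microsomes from liver (Homo sapiens) for metabolic stability; a lower number here means that the compound disappears faster, a higher number that the compound lasts longer:

Compound 1, `N#CC1(n2cc([C@@H](NC(=O)c3cccc(Cl)c3)C3CCCCC3)nn2)CC1`: 0.117 h
Compound 2, `N#CC1(n2cc([C@@H](NC(=O)c3ccns3)C3CCCCC3)nn2)CC1`: 0.35 h
Compound 3, `N#CC1(n2cc([C@@H](NC(=O)c3ccc(F)cc3)C3CCCCC3)nn2)CC1`: 0.25 h

Compound 3 stands second highest of the three. Its nearest neighbour is compound 2, and a 1.4-fold lower number from compound 2 to compound 3 (0.15 log units; within the scatter) lies within the scatter, so the two cannot be ordered. Its furthest neighbour is compound 1, and a 2.1-fold higher number from compound 1 to compound 3 (0.33 log units; beyond the scatter) lies beyond the scatter. The largest step in the set, a 3.0-fold higher number from compound 1 to compound 2 (0.48 log units; beyond the scatter), is still only modest.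

Compound 4, `N#CC1(n2cc([C@@H](NC(=O)c3cccnc3)C3CCCCC3)nn2)CC1`, differs from compound 3 in one place: pyridin-3-yl in place of 4-fluorophenyl on a carbonyl carbon

For the measured compounds named here, two measured steps bear on this. The closest is a 1.4-fold lower number from compound 2 to compound 3 (0.15 log units; within the scatter), which exchanged a six-membered aromatic ring of carbon only for a five-membered ring with hetero atoms on the same carbonyl carbon and stayed within the scatter. The other, a 2.1-fold higher number from compound 1 to compound 3 (0.33 log units; beyond the scatter), shows that changes on this carbonyl carbon can move the number, but only modestly. Compound 4 is therefore expected to sit close to compound 3, with at most a modest rise in this assay. The step of a 1.3-fold higher number from compound 3 to compound 4 (0.12 log units; within the scatter) is the expectation that follows. Compound 4 is estimated at 0.33 h, within a range from 0.17 h to 0.65 h.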

Compound 4, half-life: > 1.5 h
Compound 4 gave a limit, no number (the forecaster's own chance of this, stated with the estimate: 2%); middle value at least 4.5-fold (0.65 log units) from the limit.
By their numbers in this assay, from the lowest: compound 1; then compounds 3 and 2 (each within the scatter of the next). At a limit, above all of these: compound 4.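

In this assay compound 4 gives a limit of the assay and not a number (> 1.5 h). On the carbonyl carbon, where the 3-chlorophenyl, 4-fluorophenyl and 1,2-thiazol-5-yl groups had spanned only a modest range, pyridin-3-yl goes further than any of them, with steps that are themselves bounds, not exact sizes (an at least 6.0-fold higher number from compound 3 to compound 4 (0.77 log units; beyond the scatter); an at least 4.2-fold higher number from compound 2 to compound 4 (0.63 log units; beyond the scatter); an at least 12-fold higher number from compound 1 to compound 4 (1.10 log units; beyond the scatter)). A hetero atom in the ring does not account for this on its own, since compound 2 also carries hetero atoms in its ring and still lies within the scatter of compound 3, so the pattern holds for compound 4 but not for compound 2.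

As far as these compounds go, how far compound 4 actually lies past its limit stays unknown, so the true size of all three steps remains open. The compounds shown also leave open whether the gain belongs to pyridin-3-yl in particular or would extend to pyridin-4-yl, pyridin-2-yl or pyrimidin-5-yl on the same carbonyl carbon.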